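Amide-linked thiazolidinone series: aryl swap on the ring nitrogen

A few compounds are considered here, and "the series" means these few. Any claim that something is new, unique, unknown or untested is made for them only; others in the source may bear on it.

Three compounds of the series have been run in a functional assay on HOS-TE85 cells (Homo sapiens) for inhibition, read by CCK-8 assay, with a stated time of 72 h; a higher number here means a weaker inhibitor, a lower number a stronger inhibitor. Compound 1 `CC1SC(c2cccc(C(=O)NCCCCc3ccccc3)c2)N(c2ccc(C3CC3)cc2)C1=O` gives 191 nM in this assay. Compound 2 `O=C(NCCCCc1ccccc1)c1cccc(C2SCC(=O)N2c2cccc(-c3c[nH]nn3)c2)c1` gives 110 nM. Compound 3 `Cc1ccnc(N2C(=O)CSC2c2cccc(C(=O)NCCCCn3cccn3)c2)c1` gives 19.6 nM. Compound 2 thus holds the second highest of the three numbers; its nearest neighbour is compound 1, whose number is higher by a margin that stays within the scatter, so no order between these two is claimed. Within the data shown here, compound 3 is the furthest from compound 2, with a lower number beyond the scatter, and it is the only compound here that is separated from the others by more than the scatter.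

The next compound, compound 4 `COc1cc(F)ccc1N1C(=O)CSC1c1cccc(C(=O)NCCCCc2ccccc2)c1`, has not yet been measured. It departs from compound 2 as follows: a group of 9 heavy atoms (7 carbon, 1 oxygen, 1 fluorine; one six-membered aromatic ring of carbon only) in place of a group of 11 heavy atoms (8 carbon, 3 nitrogen; one five-membered aromatic ring with 3 hetero atoms, one six-membered aromatic ring of carbon only), on an amide-type nitrogen in a ring. The new group, 4-fluoro-2-methoxyphenyl, brings one six-membered aromatic ring of carbon only in place of a group that also carried a five-membered aromatic ring with 3 hetero atoms and a hydrogen-bond donor.

Among the measured compounds shown here, no step between measured compounds isolates this change, so the expected step in this assay from compound 2 to compound 4 rests only on the spread seen so far; a small rise, not clearly beyond the scatter, is expected, a 1.4-fold higher number from compound 2 to compound 4 (0.13 log units; within the scatter). Compound 4 is estimated at 150 nM, with a range from 50 nM to 450 nM.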

Compound 4, half-maximal inhibitory concentration: 71.1 nM
Compound 4: middle estimate off by 2.1-fold (0.32 log units), on the high side; the range from low to high includes it.
By their numbers in this assay, from the lowest: compound 3; then compounds 4, 2 and 1 (each within the scatter of the next, the first and the last beyond it).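

In this assay, among these compounds, the swap on the amide-type ring nitrogen gives a 1.5-fold lower number from compound 2 to compound 4 (0.19 log units; within the scatter), the first step that can be read at this position. The step stays within the scatter, so no order is claimed between compound 2 and compound 4, and the two numbers lie in one range even though the five-membered aromatic ring with 3 hetero atoms and its hydrogen-bond donor leave and 4-fluoro-2-methoxyphenyl enters; in this pair, then, activity in this cell assay does not depend on that ring or that donor. No supporting data are available to explain this result.

Compound 1 and compound 3 each differ from compound 4 in more than one place, so their steps to it cannot be read, and the position of compound 3 as the lowest number cannot be assigned to any single change. As far as these compounds go, it remains open whether the methoxy or the fluorine matters on its own, and what a plain phenyl or a phenyl carrying a carboxylic acid would give on this ring nitrogen.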